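Dibenzyloxy Series: Second Methoxymethyl on the Core

The source may hold more compounds than are shown below. What is called first, only, known or untested is meant among the compounds shown, and "the series" means these compounds.

Compound 3 `COCn1c(CC(COCc2ccccc2)COCc2ccccc2)c(C)c(=O)[nH]c1=O` carries a methyl on the core of compound 2 `COCn1c(CC(COCc2ccccc2)COCc2ccccc2)cc(=O)[nH]c1=O`. In a functional assay on HeLa cells (Homo sapiens) for antiproliferative activity, read by MTT assay, with a stated time of 72 h (a higher number here means a weaker inhibitor, a lower number a stronger inhibitor), compound 3 gives 29700 nM. Compound 2 gives only a limit in this assay, > 100000 nM. Compound 1 `COc1cc(CC(COCc2ccccc2)COCc2ccccc2)nc(OC)n1`, with a different core, gives 3500 nM, so compound 3 stands as the highest of the two numbers obtained, with compound 1 the nearest at a markedly lower number.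

For the measured compounds named here, the one step that can be followed, an at least 3.3-fold lower number from compound 2 to compound 3 (0.52 log units; beyond the scatter), concerns a methyl entering on an aromatic carbon; one of the three values sits at the limit of > 100000 nM in this assay, at which 1 of the 3 values shown sits, so the size of that step is only a lower bound.

Compound 4 `COCn1c(CC(COCc2ccccc2)COCc2ccccc2)c(C)c(=O)n(COC)c1=O` differs from compound 3 by methoxymethyl in place of hydrogen on an aromatic nitrogen. Going by the values given here, no measured step involves a change on an aromatic nitrogen, so the step from compound 3 to compound 4 in this assay cannot be read off from the pairs at hand. The expectation is therefore a step of no more than moderate size in either direction, and compound 4 is estimated to give 40000 nM, within 10000 nM to 150000 nM, the expected step being a 1.3-fold higher number from compound 3 to compound 4 (0.13 log units; within the scatter).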

Compound 4, half-maximal inhibitory concentration: 300 nM
The estimate for compound 4 lay 130-fold (2.12 log units) above the measured number; the measured number lies below the stated range.
By their numbers in this assay, from the lowest: compound 4; then compound 1; then compound 3. At a limit, above all of these: compound 2.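

Methoxymethyl in place of hydrogen on this aromatic nitrogen gives, in this assay, a 99-fold lower number from compound 3 to compound 4 (2.00 log units; beyond the scatter), the only step shown that is graded large. The earlier pair followed only a methyl entering on an aromatic carbon, an at least 3.3-fold lower number from compound 2 to compound 3 (0.52 log units; beyond the scatter), and the size of that step is only a lower bound: the limit of > 100000 nM in this assay, at which 1 of the 4 values shown sits. The hydrogen on this nitrogen is therefore not needed for antiproliferative activity in this pair, as compound 4 has none there and carries a methoxymethyl group on each of the two ring nitrogens.

Compound 3 and compound 4 alone do not separate the loss of the hydrogen from the entry of the methoxymethyl group, a question on which a plain methyl, a longer chain such as ethoxymethyl, or a chain ending in an amine on this nitrogen would bear. Also open, as far as these compounds go, is whether the same gain holds without the methyl on the core, and what the methoxymethyl group already present on the other ring nitrogen contributes.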